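Swapping a Chlorothiophene for Cyclopropyl on the Shared Core

The compounds below may be only part of what the source reports. "The series", "measured", "known", "first", "only" and "open" are said of these compounds alone.

Three measured compounds share one core. Compound 1 `Cc1c(Cc2ccccc2)c(NNC(=O)Nc2cc(Cl)nc(Cl)c2)nc2c1cnn2C` gives 13600 nM in a functional assay on HCT-116 cells (Homo sapiens) for cytotoxicity, read by MTT assay, with a stated time of 48 h, in the presence of a further agent that is not named here; a higher number here means that more compound is needed for the effect, a lower number that less compound is needed. Compound 2 `Cc1nn(C)c2nc(NNC(=O)Nc3cc(Cl)nc(Cl)c3)cc(-c3ccc(Cl)s3)c12` gives 42100 nM in this assay, the second highest of the three numbers. Compound 3 `CCCc1cc(NNC(=O)Nc2cc(Cl)nc(Cl)c2)nc2c1cnn2C` gives 76200 nM in this assay, a value within the usual scatter of compound 2, while the gap to compound 1 lies beyond that scatter. Compound 4 `Cc1nn(C)c2nc(NNC(=O)Nc3cc(Cl)nc(Cl)c3)cc(C3CC3)c12` has not yet been measured. It differs from compound 2 by cyclopropyl in place of 5-chlorothiophen-2-yl on an aromatic carbon. Within the data shown here, no measured pair shows this exact change, so the expected step from compound 2 to compound 4 is placed close to none: a 1.1-fold lower number from compound 2 to compound 4 (0.02 log units; within the scatter) is the estimated shift in this assay. Compound 4 is therefore expected to give about 40000 nM, in a range from 12000 nM to 130000 nM.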

Compound 4, half-maximal effective concentration: 67700 nM
The estimate for compound 4 lay 1.7-fold (0.23 log units) below the measured number, within the range that was stated.
By their numbers in this assay, from the lowest: compound 1; then compounds 2, 4 and 3 (each within the scatter of the next).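

In this assay the change from 5-chlorothiophen-2-yl to cyclopropyl on this aromatic carbon gives a 1.6-fold higher number from compound 2 to compound 4 (0.21 log units; within the scatter) and that step lies within the scatter. At this position, opposite the ring nitrogen, a five-membered aromatic ring holding sulfur and chlorine can thus give way to a three-membered ring of carbon only with no clear change in the number. No measurement here offers an explanation for this result.

As far as these compounds go, whether an amine or a carboxylic acid at this position would move the number beyond the scatter stays open. So does what a phenyl ring or a longer chain would do there.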